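The compounds below may be only part of what the source reports. "The series", "measured", "known", "first", "only" and "open" are said of these compounds alone.

Of the compounds shown here, three with a shared core have been measured in a functional assay on cells (Cancer cell lines, Homo sapiens) for cytotoxicity, read by sulforhodamine B assay, with a stated time of 48 h; a lower number here means a stronger inhibitor of growth, a higher number a weaker inhibitor of growth. Compound 1 `Oc1ccc(O)c(-c2cc(-c3ccccc3)nn2-c2ccccc2)c1` gives 37700 nM. Compound 2 `Oc1ccc(O)c(-c2cc(-c3ccc(Cl)cc3)nn2-c2ccccc2)c1`, which carries a chloro group in place of a hydrogen on an aromatic carbon, gives 8010 nM, and that step is a 4.7-fold lower number from compound 1 to compound 2 (0.67 log units; beyond the scatter). Compound 3 `NS(=O)(=O)c1ccc(-n2nc(-c3ccc(Cl)cc3)cc2-c2cc(O)ccc2O)cc1`, with a sulfamoyl group in place of a hydrogen on an aromatic carbon, gives 14700 nM; the step is a 1.8-fold higher number from compound 2 to compound 3 (0.26 log units; within the scatter). Compound 2 therefore has the lowest number of the three, with compound 3 within the scatter of it and compound 1 clearly weaker.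

Compound 4 `O=C1C=CC(=O)C(c2cc(-c3ccc(Cl)cc3)nn2-c2ccccc2)=C1` has not yet been measured. Its change from compound 2 is a group of 8 heavy atoms (6 carbon, 2 oxygen; one six-membered non-aromatic ring of carbon only) in place of a group of 8 heavy atoms (6 carbon, 2 oxygen; one six-membered aromatic ring of carbon only), on an aromatic carbon: a 2,5-dihydroxyphenyl group leaves, and a six-membered non-aromatic ring of carbon only, with four double bonds outside aromatic rings and no hydrogen-bond donors, enters on the aromatic carbon of the five-membered ring that sits next to the ring nitrogen.

Neither measured step touches this part of the molecule: one changes a chloro group, the other a sulfamoyl group, on distant aromatic carbons. The data thus give no guide to the size or direction of the step, and the expectation must stay near compound 2 with a wide range. Compound 4 is estimated at 6000 nM, with a range from 1500 nM to 25000 nM. The expected step of a 1.3-fold lower number from compound 2 to compound 4 (0.13 log units; within the scatter) is therefore small and uncertain.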

Compound 4, concentration for 50% growth inhibition: 67300 nM
Beside the measured number, compound 4's estimate is 11-fold (1.05 log units) below it; the measured number lies above the stated range.
By their numbers in this assay, from the lowest: compounds 2 and 3 (each within the scatter of the next); then compounds 1 and 4 (each within the scatter of the next).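

Among these compounds, this is the first change to the 2,5-dihydroxyphenyl group itself, on the aromatic carbon next to the ring nitrogen, and in this assay it gives an 8.4-fold higher number from compound 2 to compound 4 (0.92 log units; beyond the scatter) in a compound that keeps the 4-chlorophenyl group. So this position does respond to what sits on it, even though the entering ring has the same count of heavy atoms and of hydrogen-bond acceptors as the one that leaves; the differences are a non-aromatic ring, four double bonds outside aromatic rings, and no hydrogen-bond donors. Nothing available explains why the number rises with this change.

The compounds shown leave open which of those differences matters, for example whether a 2,5-dimethoxyphenyl group, which keeps the aromatic ring but has no hydroxyl hydrogens, would stay close to compound 2 or move towards compound 4. They also leave open whether the same replacement would shift the number by a similar amount in compound 1, which has no chloro group, or in compound 3, which carries the sulfamoyl group.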